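The source may report more compounds than this note shows. Statements on the series, on what has been measured and on what is new or still open speak of the compounds shown alone.

In a functional assay on PC-12 cells (Rattus norvegicus) for cytotoxicity, read by MTT assay, with stated times of 3 h and 2 h, tested at 10 uM (a higher number here means a stronger effect of the compound at the concentration tested, a lower number a weaker effect), compound 3 `O=C(CCCCC1CCSS1)NCc1cn(CCCOc2ccc3cc(C(=O)O)c(=O)oc3c2)nn1` gives 59.9%, the second highest of the three numbers. Compound 1 `Cc1cc(=O)oc2cc(OCCCn3cc(CNC(=O)CCCCC4CCSS4)nn3)ccc12` gives 69.4% in this assay, within the scatter of compound 3. Compound 2 `CCOC(=O)c1cc2ccc(OCCCn3cc(CNC(=O)CCCCC4CCSS4)nn3)cc2oc1=O` gives 36.1%, and the step of a number 23.8 percentage points higher from compound 2 to compound 3 (beyond the scatter) was a modest rise beyond the scatter, for hydrogen in place of ethyl on an oxygen next to a carbonyl group. Compound 4 `O=C(CCCCC1CCSS1)NCc1cn(CCCOc2ccc3cc(-c4ccc(Cl)cc4)c(=O)oc3c2)nn1` has not been measured in this assay. It differs from compound 3 by 4-chlorophenyl in place of carboxy on an aromatic carbon. Among the measured compounds shown here, no measured step exchanges a carboxy for an aryl group, so the one step at this site gives no direct guide. For compound 4 the expected step of a number 4.9 percentage points lower from compound 3 to compound 4 (within the scatter) is therefore not beyond the scatter in either direction, with a wide range. Compound 4 is estimated at 55%, between 35% and 75%.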

Compound 4, a percentage reported as activity, at one concentration (the size of the read-out at that concentration, not a potency): 67.8%
For compound 4 the middle estimate is 12.8 percentage points below the measured one; the measured number falls inside the stated range.
By their numbers in this assay, from the lowest: compound 2; then compounds 3, 4 and 1 (each within the scatter of the next).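

In this assay this aromatic carbon takes 4-chlorophenyl, with its six-membered aromatic ring and no hydrogen-bond donor, in place of carboxy, with a number 7.9 percentage points higher from compound 3 to compound 4 (within the scatter) and no separation between the two groups. Set against ethoxycarbonyl, the same group gives a number 31.7 percentage points higher from compound 2 to compound 4 (beyond the scatter) and so, of the three groups at this carbon, ethoxycarbonyl alone stands apart. No measurement available here accounts for this. From the compounds shown here alone, whether an unsubstituted phenyl or an amine at this carbon stays level with carboxy and 4-chlorophenyl remains open. So does whether the lower reading extends to a methyl ester or a primary amide.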